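The source may report more compounds than this note shows. Statements on the series, on what has been measured and on what is new or still open speak of the compounds shown alone.

Compound 1 `O=C1CCC2(c3ccc(F)cc3)OCCCN12` is the reference point of this small set. In a functional assay on the whole organism (Central nervous system) with Mus musculus as the target (a lower number here means that less compound is needed, a higher number that more compound is needed for the effect), compound 1 gives 100 mg/kg, the lowest of the two plain numbers recorded. Compound 2 `O=C(CCC(=O)c1ccc(F)cc1)NCCCO`, the open-chain counterpart of the shared core, gives 500 mg/kg in this assay, a gap from compound 1 that lies beyond the usual scatter of the measurement. Compound 3 `O=C1CCC2(c3ccc(Cl)c(Cl)c3)OCCCN12` is reported only as a limit of this assay, < 150 mg/kg, so it stands as the limit of < 150 mg/kg in this assay, at which 1 of the 3 values shown sits, rather than as a number.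

Compound 4 `Cc1ccc(C23CCC(=O)N2CCCO3)cc1` has not yet been measured. It differs from compound 1 in a single place: methyl in place of fluoro on an aromatic carbon. Among the compounds with values here, no pair of measured compounds here differs in just this way, so the step has no direct precedent in the data. The account therefore treats the change as a small one at the edge of the shared core, carrying no expectation of a shift beyond the scatter in either direction.

For compound 4 the expected value in this assay is 120 mg/kg, with a range from 50 mg/kg to 300 mg/kg. The step from compound 1 to compound 4 that this estimate implies, a 1.2-fold higher number from compound 1 to compound 4 (0.08 log units; within the scatter), is expected to stay within the ordinary scatter of repeated measurements.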

Compound 4, dose for half-maximal effect: 160 mg/kg
The estimate for compound 4 lay 1.3-fold (0.12 log units) below the measured number; low and high end bracket the measured number.
By their numbers in this assay, from the lowest: compounds 1 and 4 (each within the scatter of the next); then compound 2.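

In this assay, methyl in place of fluoro on an aromatic carbon, para to a large group, amounts to a 1.6-fold higher number from compound 1 to compound 4 (0.20 log units; within the scatter), so this position takes either group without a difference that can be told from the scatter. Within the data shown here, this is the first comparison in the set between compounds that differ in one place, and it shows that exchanging one heavy atom for another at this position leaves compound 1 and compound 4 without an order between them. Nothing measured here bears on why the two compounds stand so close.

Among these compounds, only this one exchange at this one position can be read, so it remains open whether an amine, a carboxylic acid or a longer chain at the same aromatic carbon would stay as close to compound 1, and whether other parts of the shared core tolerate change as well. Compound 3 stays a limit rather than a number: the limit of < 150 mg/kg in this assay, at which 1 of the 4 values shown sits.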